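Cyclic sulfonamide replaced by an open-chain amide

A few compounds are considered here, and "the series" means these few. Any claim that something is new, unique, unknown or untested is made for them only; others in the source may bear on it.

The series shares one core, seen in compound 1 `CC(C)C(c1ccc(-c2ccc3cccc(F)c3c2)[nH]c1=O)N1CCCCS1(=O)=O`, which carries a six-membered ring with two hetero atoms on the saturated chain carbon bound to the aromatic carbon. In an ADME assay on microsomes from liver (Homo sapiens) for metabolic stability (a higher number here means that the compound lasts longer, a lower number that the compound disappears faster), compound 1 gives 0.373 h. Among the compounds with values here, compound 2 `CC(C)[C@@H](C[C@H]1CCNC1=O)c1ccc(-c2ccc3cccc(F)c3c2)[nH]c1=O` is the only other compound measured; in this assay compound 2 gives 0.693 h, and the two numbers lie within the scatter of each other, so compound 1 stands alongside compound 2 rather than apart from it.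

Compound 3 `CC(C)NC(=O)CC(c1ccc(-c2ccc3cccc(F)c3c2)[nH]c1=O)C(C)C` has not yet been measured. Relative to compound 1 it differs in one place: a group of 7 heavy atoms (5 carbon, 1 nitrogen, 1 oxygen; no ring) in place of a group of 8 heavy atoms (4 carbon, 1 nitrogen, 2 oxygen, 1 sulfur; one six-membered non-aromatic ring with 2 hetero atoms), on a saturated chain carbon bound to an aromatic carbon and a saturated chain carbon. Within the data shown here, no step between measured compounds resembles this change, so nothing measured sets its size. Because compound 1 gives 0.373 h and compound 2 gives 0.693 h, both short, the author expects the half-life of compound 3 to remain in the same region, with a step of a 1.3-fold higher number from compound 1 to compound 3 (0.13 log units; within the scatter) that is modest and not clearly beyond the scatter. The author's estimate for compound 3 in this assay is 0.5 h, expected to fall between 0.2 h and 1.2 h.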

Compound 3, half-life: 0.32 h
Estimate against measurement, compound 3: 1.6-fold (0.19 log units) above, within the range that was stated.
By their numbers in this assay, from the lowest: compounds 3, 1 and 2 (each within the scatter of the next, the first and the last beyond it).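

In this assay, within the data shown here, placing (isopropylcarbamoyl)methyl on the saturated chain carbon instead of the six-membered ring of compound 1 gives a 1.2-fold lower number from compound 1 to compound 3 (0.07 log units; within the scatter) and so provides the first step that can be read at this position. The half-lives of this pair cannot be told apart, so at this position an open chain carrying an amide and a ring carrying sulfur give the same result within the scatter, although the two groups share neither ring nor sulfur. Nothing measured here bears on why the two half-lives agree.

The compounds shown leave open whether an amine, a carboxylic acid or a longer chain on this saturated chain carbon would give a half-life beyond the scatter of compound 1. They also leave open what the ring and the sulfur each contribute on their own, which a six-membered ring without sulfur or an open-chain sulfonamide at the same place could separate.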